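The source may hold more compounds than are shown below. What is called first, only, known or untested is meant among the compounds shown, and "the series" means these compounds.

Three compounds have been measured so far in a functional assay on PC-3 cells (Homo sapiens) for cytotoxicity, read by WST assay, with a stated time of 72 h (on this read-out higher numbers stand for weaker inhibition and lower numbers for stronger inhibition), and give these values:

- Compound 1 `Cc1ccc(C2(c3ccc(O)cc3)C(=O)Nc3c2ccc(F)c3F)cc1` gives 0.8 nM
- Compound 2 `CCOc1ccc(C2(c3ccc(O)cc3)C(=O)Nc3c2ccc(F)c3F)cc1` gives 24 nM
- Compound 3 `CCCC1(c2ccc(O)cc2)C(=O)Nc2c1ccc(F)c2F` gives > 1000 nM

The value of compound 3 is a limit of the assay and not a number. It stands at the limit of > 1000 nM in this assay, at which 1 of the 3 values shown sits, and is the weakest of the three, with its steps to both others beyond the scatter.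

Compound 4 `O=C1Nc2c(ccc(F)c2F)C1(Cc1ccccc1)c1ccc(O)cc1` departs from compound 3 by phenyl in place of ethyl on a saturated chain carbon bound to a saturated ring carbon, or propyl to benzyl.

The closest evidence comes from the two steps that replace an aromatic group on the saturated ring carbon with propyl, an at least 1200-fold higher number from compound 1 to compound 3 (3.09 log units; beyond the scatter) and an at least 41-fold higher number from compound 2 to compound 3 (1.61 log units; beyond the scatter). Both are large and point the other way. Compound 4 regains an aromatic ring, but on the chain carbon and not on the ring carbon itself, so only part of that loss is expected to be recovered. The step of a 30-fold higher number from compound 1 to compound 2 (1.48 log units; beyond the scatter) adds a caution, since a change on the aromatic group alone moved the number widely.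

A step to a lower number in this assay is therefore expected, smaller than those two, and it is estimated as an at least 5.0-fold lower number from compound 3 to compound 4 (0.69 log units; beyond the scatter) in size. For compound 4 the expected value is 200 nM, with an estimated range from 20 nM to 1000 nM.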

Compound 4, half-maximal inhibitory concentration: > 1000 nM
Compound 4 gave a limit, no number; the forecaster's own chance of this, stated with the estimate: 25%; middle value at least 5.0-fold (0.69 log units) from the limit.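

In this assay compound 4 gives only a limit of the assay and not a number, as compound 3 does: the limit of > 1000 nM in this assay, at which 2 of the 4 values shown sit.

The step between these two compounds cannot be read. Benzyl in place of 4-methylphenyl on the saturated ring carbon gives an at least 1200-fold higher number from compound 1 to compound 4 (3.09 log units; beyond the scatter), and benzyl in place of 4-ethoxyphenyl at the same place gives an at least 41-fold higher number from compound 2 to compound 4 (1.61 log units; beyond the scatter); both steps are large and beyond the scatter, so an aromatic ring carried on the chain carbon does not by itself restore a value like those seen with the two substituted phenyl groups on the ring carbon.

As far as these compounds go, how far compound 3 and compound 4 lie past the limit stays open, and with it whether benzyl differs from propyl at all in this assay. Also open, from the compounds shown here alone, is what other groups on the saturated ring carbon would give, such as a 2-phenylethyl chain, a pyridine ring or a phenyl ring carrying an amine, and whether any of them would come back towards the values of the substituted phenyl compounds.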